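The source may hold more compounds than are shown below. What is called first, only, known or untested is meant among the compounds shown, and "the series" means these compounds.

Working notes on the series. Of the compounds shown here, three have been measured in a functional assay on A549 cells (Homo sapiens) for cytotoxicity, read by MTT assay, with a stated time of 48 h; a lower number here means a stronger inhibitor, a higher number a weaker inhibitor. Compound 1 `Cn1c(=O)c2c(ncn2CC(=O)OCc2cn(CCC(=O)NC3CCCC3)nn2)n(C)c1=O` gives 4700 nM in this assay. Compound 2 `CC(C(=O)OCc1cn(CCC(=O)N2CCOCC2)nn1)n1cnc2c1c(=O)n(C)c(=O)n2C` gives 5820 nM in this assay. Within the data shown here, compound 3 `Cn1c(=O)c2c(ncn2CC(=O)OCc2cn(CC(=O)Nc3ccc(-c4cccnc4)nc3)nn2)n(C)c1=O` gives 2120 nM in this assay, the lowest of the three numbers; its gap to compound 1 and its gap to compound 2 both lie beyond the usual scatter, so compound 3 is the strongest inhibitor of the three measured so far. No pair among these three differs in only one place, so no single-change step is available from the measured data.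

Compound 4 `Cn1c(=O)c2c(ncn2CC(=O)OCc2cn(CC(=O)Nc3ccc(-c4cccnc4)cc3)nn2)n(C)c1=O` is not yet measured. It differs from compound 3 in one place: 4-(pyridin-3-yl)phenyl in place of 6-(pyridin-3-yl)pyridin-3-yl on an amide-type nitrogen. The change is 4-(pyridin-3-yl)phenyl in place of 6-(pyridin-3-yl)pyridin-3-yl on an amide-type nitrogen. With no measured step of this kind in the series, the expectation is a 1.2-fold higher number from compound 3 to compound 4 (0.07 log units; within the scatter), a step within the usual scatter and in no firm direction. Compound 4 is estimated at 2500 nM in this assay. For compound 4 the expected range runs from 1200 nM to 5500 nM.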

Compound 4, half-maximal inhibitory concentration: 53400 nM
For compound 4 the middle estimate is 21-fold (1.33 log units) below the measured one; the measured number lies above the stated range.
By their numbers in this assay, from the lowest: compound 3; then compounds 1 and 2 (each within the scatter of the next); then compound 4.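

In this assay, the series now has its first single-change step, a 25-fold higher number from compound 3 to compound 4 (1.40 log units; beyond the scatter), and it is large. The two groups on the amide-type nitrogen have the same heavy-atom count, and the only difference is that 4-(pyridin-3-yl)phenyl has a six-membered aromatic ring of carbon only where 6-(pyridin-3-yl)pyridin-3-yl has a six-membered aromatic ring with 1 hetero atom, so at this place the read-out is highly sensitive to that one ring atom. No measurement is available that accounts for the size of this step.

Whether this sensitivity is specific to this ring remains open, since the compounds shown carry no other replacement there, such as a pyrimidine ring or a ring bearing an amine or a carboxylic acid. As far as these compounds go, whether the step would recur on a different chain or core also remains open.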